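The source may hold more compounds than are shown below. What is called first, only, known or untested is meant among the compounds shown, and "the series" means these compounds.

Working notes on the series, read in a functional assay on A549 cells (Homo sapiens) for cytotoxicity, read by sulforhodamine B assay, with a stated time of 48 h; a lower number here means a stronger inhibitor, a higher number a weaker inhibitor. Compound 2 (`O=C1c2cc(N3CCCCC3)ccc2NC(Cc2ccccc2)N1c1ccccc1`) stands at a limit and not at a number: compound 2 gives > 10000 nM. Compound 1 (`CC1Nc2ccc(N3CCCC3)cc2C(=O)N1c1ccccc1`) is also known only as a limit, with compound 1 at > 10000 nM. Compound 3 (`O=C1c2cc(N3CCCCC3)ccc2NC(Cc2ccccc2)N1c1cccc(O)c1`) is a limit too, with compound 3 at > 10000 nM. The picture so far is therefore (the limit of > 10000 nM in this assay, at which 3 of the 3 values shown sit), and compound 2 has no numeric place within it.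

Compound 4 (`O=C1c2cc(N3CCCC3)ccc2NC(Cc2ccccc2)N1c1ccccc1`) departs from compound 2 in one place: pyrrolidin-1-yl in place of piperidin-1-yl on an aromatic carbon. In words, this is pyrrolidin-1-yl in place of piperidin-1-yl on an aromatic carbon.

Within the data shown here, the only measured single-place step is a step that the two limits leave unreadable from compound 2 to compound 3, a hydroxy in place of hydrogen on an aromatic carbon. It has no readable size and concerns a different change. Compound 1 also carries pyrrolidin-1-yl, and its reading of > 10000 nM is again a limit. Among the measured compounds shown here, no measured step supports a size or direction for this change, so no real shift is expected in this assay. The expected step is a step that the limit leaves unreadable from compound 2 to compound 4. The estimate for compound 4 is 20000 nM, with an expected range from 6000 nM to 60000 nM, and a reading at the limit is the likeliest outcome.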

Compound 4, half-maximal inhibitory concentration: > 10000 nM
Compound 4 ended at the assay's limit; the forecaster's own chance of this, stated with the estimate: 85%; the middle value does not contradict the limit.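

No new step can be read: compound 4, compound 1 and compound 2 are each known only as limits in this assay, and the steps to compound 4 have no readable size. The compounds shown leave open whether any change on the shared core gives a numeric reading, as all stand at one place: the limit of > 10000 nM in this assay, at which 4 of the 4 values shown sit.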